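Methoxy to chloro: a small expected step

The source may report more compounds than this note shows. Statements on the series, on what has been measured and on what is new or still open speak of the compounds shown alone.

In a functional assay on HepG2 cells (Homo sapiens) for antiproliferative activity, read by MTT assay, with a stated time of 72 h (on this read-out lower numbers stand for stronger inhibition and higher numbers for weaker inhibition), compound 1 (`O=C1COc2ccc(-c3cnc(Cl)c(NS(=O)(=O)c4ccc(F)cc4)c3)cc2N1c1ccc(Cl)cc1`) gives 33900 nM and compound 2 (`COc1ccc(N2C(=O)COc3ccc(-c4cnc(OC)c(NS(=O)(=O)c5ccc(F)cc5)c4)cc32)cc1`) gives 13100 nM as the lower of the two numbers, a gap beyond the scatter. Compound 3 (`COc1ncc(-c2ccc3c(c2)N(c2ccc(Cl)cc2)C(=O)CO3)cc1NS(=O)(=O)c1ccc(F)cc1`) differs from compound 2 in one place, with chloro in place of methoxy on an aromatic carbon, so that 4-methoxyphenyl becomes 4-chlorophenyl (chloro in place of methoxy on an aromatic carbon). Within the data shown here, no measured step shows this change alone. With only compound 1 (33900 nM) as a guide, a small rise in this assay is expected, possibly none beyond the scatter. The estimate is thus a 1.4-fold higher number from compound 2 to compound 3 (0.14 log units; within the scatter) as an expected step. Compound 3 is estimated at 18000 nM (expected range 7000 nM to 40000 nM).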

Compound 3, half-maximal inhibitory concentration: 17900 nM
Compound 3: middle estimate off by 1.0-fold (0.00 log units), on the high side; the measured number falls inside the stated range.
By their numbers in this assay, from the lowest: compounds 2, 3 and 1 (each within the scatter of the next, the first and the last beyond it).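

In this assay, replacing 4-methoxyphenyl with 4-chlorophenyl on its own gives a 1.4-fold higher number from compound 2 to compound 3 (0.14 log units; within the scatter) so at this position the two groups cannot be told apart. The same kind of swap at another aromatic carbon, methoxy in place of chloro, gives a 1.9-fold lower number from compound 1 to compound 3 (0.28 log units; within the scatter) which is also within the scatter, although compound 1 and compound 2, which differ at both places, lie beyond it. Nothing measured here offers a reason for these steps. Going by these compounds, what an amine or a carboxylic acid would do in place of the methoxy or chloro on this phenyl ring remains open.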